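A few compounds are considered here, and "the series" means these few. Any claim that something is new, unique, unknown or untested is made for them only; others in the source may bear on it.

Working notes on the chloroacetyl urea series.

Compound 1 `O=C(CCl)NC(=O)Nc1ccc(Oc2ccccc2)cc1` and compound 2 `O=C(CCl)NC(=O)Nc1cccc(Oc2ccccc2)c1` are built from the same atoms joined differently; the difference between the two cores is not broken down here. In a functional assay on M21 cells (Homo sapiens) for inhibition, read by sulforhodamine B assay, with a stated time of 48 h (a lower number here means a stronger inhibitor of growth, a higher number a weaker inhibitor of growth), compound 1 gives 4200 nM, and in the same assay compound 2 gives 5300 nM. The two numbers lie within the scatter of each other, so no order between them is read.

Compound 3 `O=C(CCl)NC(=O)Nc1ccc(OCc2ccccc2)cc1` is obtained from compound 1 by the change (benzyl in place of phenyl on an oxygen on an aromatic ring). In this assay compound 3 gives 5100 nM. The resulting step, a 1.2-fold higher number from compound 1 to compound 3 (0.08 log units; within the scatter), is within the scatter, so the change left growth inhibition essentially unchanged on the core of compound 1. Compound 2 and compound 3 also lie within the scatter of each other.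

Compound 4 `O=C(CCl)NC(=O)Nc1cccc(OCc2ccccc2)c1` has not yet been measured. It differs from compound 2 by benzyl in place of phenyl on an oxygen on an aromatic ring, and the surroundings of the place are described in the same words as for the change from compound 1 to compound 3; this change therefore occurs twice among the compounds shown, once measured and once pending.

The step from compound 2 to compound 4 in this assay is expected to be small, a 1.1-fold higher number from compound 2 to compound 4 (0.05 log units; within the scatter), because the earlier step of a 1.2-fold higher number from compound 1 to compound 3 (0.08 log units; within the scatter) stayed within the scatter and there is no indication in the set that the core of compound 2 responds differently. For compound 4 in this assay the estimate is 6000 nM, expected to fall between 3000 nM and 12000 nM.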

Compound 4, concentration for 50% growth inhibition: 4500 nM
Compound 4: middle estimate off by 1.3-fold (0.12 log units), on the high side; the range from low to high includes it.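

The new step in this assay is a 1.2-fold lower number from compound 2 to compound 4 (0.07 log units; within the scatter), so benzyl in place of phenyl on an oxygen on an aromatic ring leaves growth inhibition essentially unchanged on the core of compound 2, as it did on the core of compound 1. Set side by side, the two steps do not differ, so within these two cores the change carries over without a measurable effect on either: the same change on two cores in this assay, a 1.2-fold higher number (0.08 log units; within the scatter) from compound 1 to compound 3 and a 1.2-fold lower number (0.07 log units; within the scatter) from compound 2 to compound 4, 1.4-fold (0.16 log units) apart, within the scatter of two such steps

This is agreement between two small steps in a single assay, so it shows only that the absence of an effect repeats on a second core; it does not show that a step of real size would carry over, that the change would behave the same way on any other core, or that the opposite directions of the two steps mean anything.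

As far as these compounds go, all four compounds carry an unsubstituted phenyl or benzyl on the oxygen and the same chloroacetyl urea, so it remains open what, if anything, moves the number beyond the scatter. Open questions include a longer chain such as phenethyl on that oxygen, an amine or a carboxylic acid on the phenyl or benzyl group, and a plain acetyl in place of the chloroacetyl group.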